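From Compound 1 to Compound 4: An Ether Extension

A few compounds are considered here, and "the series" means these few. Any claim that something is new, unique, unknown or untested is made for them only; others in the source may bear on it.

Compound 1, `COc1cc(OC)c(C(C)=O)c(OC)c1`, gives > 20000 nM in a functional assay on REH cells (Homo sapiens) for cytotoxicity, read by resazurin assay, with a stated time of 72 h; on this read-out lower numbers stand for stronger inhibition and higher numbers for weaker inhibition; this is a limit of the assay, not a number.
Compound 2, `COc1cc(OC)c(C(=O)/C=C/c2ccccc2)c(OC)c1`, gives > 20000 nM in this assay; this too is a limit of the assay.
Compound 3, `C=CCOc1ccccc1Cc1c(OC)cc(OC)c(C(=O)/C=C/c2ccccc2)c1OC`, gives 12600 nM in this assay.

Compound 1 therefore stands at the limit of this assay, where two of the three values shown sit (the limit of > 20000 nM in this assay, at which 2 of the 3 values shown sit); only compound 3 yields a measured number. For the measured compounds named here, the single measured step, an at least 1.5-fold lower number from compound 2 to compound 3 (0.20 log units; that floor lies within the scatter), comes from placing 2-(allyloxy)benzyl in place of hydrogen on an aromatic carbon, and even that step is not clearly beyond the scatter.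

Compound 4, `COCOc1cc(OC)cc(OC)c1C(C)=O`, is the unmeasured partner of compound 1. The change is methoxy in place of hydrogen on a saturated chain carbon bound to an oxygen on an aromatic ring. Going by the values given here, no measured step touches a saturated chain carbon bound to an oxygen on an aromatic ring, so the step from compound 2 to compound 3, which alters an aromatic carbon, bears on it only loosely and offers no direction. Compound 4 is thus expected to remain near the limit of this assay, with the expected step that the limit leaves unreadable from compound 1 to compound 4 being none beyond the scatter. For compound 4 the estimated value in this assay is 25000 nM, within a range from 12000 nM to 60000 nM, most likely reported again as a limit.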

Compound 4, half-maximal inhibitory concentration: > 20000 nM
Compound 4 ended at the assay's limit; the forecaster's own chance of this, stated with the estimate: 80%; the middle value lies beyond the limit too.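

For the compounds shown here, compound 1 and compound 4 both stand at a limit of this assay, so the step between them cannot be read and no new step emerges: the limit of > 20000 nM in this assay, at which 3 of the 4 values shown sit. The compounds shown leave open how far either compound lies past that limit, and whether methoxy in place of hydrogen on that saturated chain carbon changes the read-out at all.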